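The compounds below may be only part of what the source reports. "The series", "measured", "known", "first", "only" and "open" are said of these compounds alone.

Measured compounds in a functional assay on the whole organism (integument) for inhibition, with Chilo suppressalis as the target, read by scintillation counting, with a stated time of 72 h; on this read-out higher numbers stand for weaker inhibition and lower numbers for stronger inhibition:
- compound 1 `COc1cccc(OC)c1C(=O)Nc1nnc(-c2ccc(Cl)cc2)s1` gives 58.9 nM
- compound 2 `COc1cccc(OC)c1C(=O)Nc1nnc(-c2ccc(C#N)cc2)s1` gives 209 nM
- compound 3 `CCOc1ccc(-c2nnc(NC(=O)c3c(OC)cccc3OC)s2)cc1` gives 646 nM

Compound 3 stands at the highest number of the three in this assay; its nearest neighbour is compound 2, as a 3.1-fold higher number from compound 2 to compound 3 (0.49 log units; beyond the scatter) shows, and the furthest is compound 1, as an 11-fold higher number from compound 1 to compound 3 (1.04 log units; beyond the scatter) shows. Every exchange at this aromatic carbon so far has moved the number beyond the scatter: a 3.5-fold higher number from compound 1 to compound 2 (0.55 log units; beyond the scatter) and the two steps just named.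

Compound 4 `COc1cccc(OC)c1C(=O)Nc1nnc(-c2ccc(-c3ccccc3)cc2)s1` differs from compound 3 by phenyl in place of ethoxy on an aromatic carbon. Going by the values given here, no measured step involves a phenyl at this position, so none bears on it directly; the three steps only show that the group at this carbon matters, with shifts from modest to large. The entering group is counted as larger than any of the three groups compared so far, and the step from compound 3 is therefore expected to be of modest size in this assay, more likely upward than downward, with a broad range of uncertainty: a 1.9-fold higher number from compound 3 to compound 4 (0.27 log units; within the scatter).

Compound 4 is estimated at 1200 nM in this assay, within 300 nM to 5000 nM.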

Compound 4, half-maximal inhibitory concentration: 195 nM
Beside the measured number, compound 4's estimate is 6.2-fold (0.79 log units) above it, and the stated range ends above it.
By their numbers in this assay, from the lowest: compound 1; then compounds 4 and 2 (each within the scatter of the next); then compound 3.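

Phenyl brings 6 heavy atoms in place of the 3 of ethoxy, yet in this assay the larger group does not weaken inhibition further: the series shows a 3.3-fold lower number from compound 3 to compound 4 (0.52 log units; beyond the scatter), so a ring at this aromatic carbon is tolerated better than ethoxy. Phenyl and cyano cannot be told apart on this read-out, with a 1.1-fold lower number from compound 2 to compound 4 (0.03 log units; within the scatter), even though the two groups share little in shape or make-up, whereas chloro keeps its lead over phenyl, with a 3.3-fold higher number from compound 1 to compound 4 (0.52 log units; beyond the scatter), and compound 1 remains the strongest of the four. The size of the group therefore does not order these compounds, with compound 3 going against any simple rise in the number as the group grows, and nothing at hand gives a reason for the order found.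

Still open, on these data alone, is how a bromine atom, a methyl group, an amine, a carboxylic acid or a longer alkoxy chain would fall at this carbon relative to chloro and ethoxy. Also open, as far as these compounds go, is whether a substituted phenyl would move the number away from compound 4, and whether the order seen here holds when another part of the shared core changes.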